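The source may hold more compounds than are shown below. What is called first, only, known or untested is meant among the compounds shown, and "the series" means these compounds.

Compound 1, `ClCc1ccc(Cn2cnc3c(Cl)ncnc32)cc1`, and compound 3, `ClCc1ccccc1Cn1cnc2c(Cl)ncnc21`, are built from the same atoms joined differently; how the two cores differ is not broken down here. Compound 2, `Nc1nc(Cl)c2ncn(Cc3ccc(CCl)cc3)c2n1`, is compound 1 carrying the change (amino in place of hydrogen on an aromatic carbon). In a functional assay on SK-OV-3 cells (Homo sapiens) for cytotoxicity, read by sulforhodamine B assay, with a stated time of 48 h (a higher number here means that more compound is tolerated, a lower number that less compound is tolerated), compound 1 gives 91200 nM. In this assay compound 2 gives 64500 nM, and the step of a 1.4-fold lower number from compound 1 to compound 2 (0.15 log units; within the scatter). In this assay compound 3 gives 85100 nM, a value that, like those of compound 1 and compound 2, lies within the scatter of the other two, so no order among the three can be read from the numbers.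

Compound 4, `Nc1nc(Cl)c2ncn(Cc3ccccc3CCl)c2n1`, has not yet been measured. It stands to compound 3 exactly as compound 2 stands to compound 1: the change is amino in place of hydrogen on an aromatic carbon, the same change that was made once before, at a place described in the same words. Because the step of a 1.4-fold lower number from compound 1 to compound 2 (0.15 log units; within the scatter) stayed within the scatter, compound 4 is expected to show a step of a 1.3-fold lower number from compound 3 to compound 4 (0.12 log units; within the scatter), little more than a repeat of what the earlier pair showed. In this assay compound 4 is therefore estimated at 65000 nM, with an expected range from 35000 nM to 120000 nM. Whether the second occurrence of the change behaves like the first is the question the next measurement will answer.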

Compound 4, concentration lethal to 50% of the cells: > 100000 nM
Compound 4: no number, only a limit; the forecaster's own chance of this, stated with the estimate: 5%; middle value at least 1.5-fold (0.18 log units) from the limit.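

Compound 4 carries no number, only a limit of the assay: the limit of > 100000 nM in this assay, at which 1 of the 4 values shown sits. Read as a floor, the step is an at least 1.1-fold higher number from compound 3 to compound 4 (0.07 log units; that floor lies within the scatter), so all that can be said is that amino in place of hydrogen on the core of compound 3 gives no fall in the number, while the true size of the step stays unknown. Set beside the step on the core of compound 1, this does not show that the change carries over from one core to the other unaltered, nor does it show that the two cores respond differently: the same change on two cores in this assay, a 1.4-fold lower number (0.15 log units; within the scatter) from compound 1 to compound 2 and an at least 1.1-fold higher number (0.07 log units; that floor lies within the scatter) from compound 3 to compound 4; the limit leaves it open whether they differ.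

The compounds shown carry only hydrogen or amino at this aromatic carbon, so they leave open how a methyl group, a hydroxyl group or a longer chain in that place would read in this assay. On these data alone, all four compounds also keep the chloro group, and what an amine or a carboxylic acid in its place would give on either core remains open, as does any firm comparison of the two cores until compound 4 has a number rather than a limit.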